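Alkyl size at the aromatic carbon: outlook for compound 3

A few compounds are considered here, and "the series" means these few. Any claim that something is new, unique, unknown or untested is made for them only; others in the source may bear on it.

Measured so far:
compound 1 `Fc1ccccc1-c1ccc2[nH]ncc2c1` — 3950 nM
compound 2 `CCc1ccccc1-c1ccc2[nH]ncc2c1` — 584 nM

In an assay on CHO-TREX cells for antagonist activity at transient receptor potential cation channel subfamily A member 1 (Homo sapiens), read by FLIPR and calcium flux, with a stated time of 10 min (a lower number here means a stronger inhibitor, a higher number a weaker inhibitor), compound 2 gives 584 nM and stands lowest of the two numbers; the nearest is compound 1 with 3950 nM. Going by the values given here, the one measured step in this assay is a 6.8-fold lower number from compound 1 to compound 2 (0.83 log units; beyond the scatter), which came from ethyl in place of fluoro on an aromatic carbon.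

Compound 3 `CC(C)c1ccccc1-c1ccc2[nH]ncc2c1` differs from compound 2 by methyl in place of hydrogen on a saturated chain carbon bound to an aromatic carbon and a saturated chain carbon. Among the compounds with values here, no measured pair repeats this exact change. Within the data shown here, the only step that bears on it is a 6.8-fold lower number from compound 1 to compound 2 (0.83 log units; beyond the scatter), which also enlarged the group on the same aromatic carbon and lowered the number in this assay by a modest amount. On that single precedent a smaller further lowering is expected in this assay, namely a 1.7-fold lower number from compound 2 to compound 3 (0.22 log units; within the scatter), though a result within the scatter would not surprise. Compound 3 is therefore estimated at 350 nM in this assay, with a range of 120 nM to 1000 nM.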

Compound 3, half-maximal inhibitory concentration: 514 nM
The estimate for compound 3 lay 1.5-fold (0.17 log units) below the measured number; measured number inside the range.
By their numbers in this assay, from the lowest: compounds 3 and 2 (each within the scatter of the next); then compound 1.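

In this assay, the change from ethyl to isopropyl gives a 1.1-fold lower number from compound 2 to compound 3 (0.06 log units; within the scatter), so methyl in place of hydrogen on the saturated chain carbon bound to an aromatic carbon and a saturated chain carbon adds nothing measurable to the gain seen when ethyl replaced fluoro. Isopropyl in place of fluoro gives a 7.7-fold lower number from compound 1 to compound 3 (0.89 log units; beyond the scatter), so the separation from compound 1 holds for both alkyl groups, while compound 2 and compound 3 cannot be told apart in this series. No measurement at hand accounts for this flat result from ethyl to isopropyl.

The compounds shown leave open how a tert-butyl group or a longer chain on the same aromatic carbon would read in this assay. Also open, from the compounds shown here alone, is whether a plain methyl group there would match ethyl, and how an amine or a carboxylic acid at that carbon would compare.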